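The source may report more compounds than this note shows. Statements on the series, on what has been measured and on what is new or still open speak of the compounds shown alone.

Working notes on the series. Compound 1 `Cc1noc(NS(=O)(=O)c2cccc3c(CN(C)C)cccc23)c1C` gives 2800 nM in an assay on VSM-A10 cells for antagonist activity at Endothelin-1 receptor (Rattus norvegicus) (a higher number here means a weaker inhibitor, a lower number a stronger inhibitor), the higher of the two numbers in hand. Going by the values given here, compound 2 `Cc1noc(NS(=O)(=O)c2ccc3cc(N)ccc3c2)c1C` gives 660 nM in this assay, a gap beyond the scatter, though the two structures differ in more than one place and no single step links them. Compound 3 `CCOC(=O)C(C)Nc1cccc2c(S(=O)(=O)Nc3onc(C)c3C)cccc12` differs from compound 1 by (1-(ethoxycarbonyl)ethyl)amino in place of (dimethylamino)methyl on an aromatic carbon. Among the compounds with values here, no measured step covers this change, so the expectation rests on little. A modest step toward a lower number is expected, a 1.9-fold lower number from compound 1 to compound 3 (0.27 log units; within the scatter). Compound 3 is thus expected near 1500 nM, within 400 nM to 5000 nM.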

Compound 3, half-maximal inhibitory concentration: 400 nM
For compound 3 the middle estimate is 3.8-fold (0.57 log units) above the measured one; measured number inside the range.
By their numbers in this assay, from the lowest: compounds 3 and 2 (each within the scatter of the next); then compound 1.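

Going by these compounds alone, on an aromatic carbon of the core of compound 1, (1-(ethoxycarbonyl)ethyl)amino in place of (dimethylamino)methyl gives a 7.0-fold lower number from compound 1 to compound 3 (0.85 log units; beyond the scatter) in this assay, the first single-place step. This position therefore tolerates the larger group, and the number moves beyond the scatter. Nothing in hand explains this step.

On these data alone, the change alters the attached nitrogen, the chain and the ethoxycarbonyl together, so which part carries the step stays open. A plain amino group or a carboxylic acid at this position would help separate these parts.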